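Positional shift of the methoxyphenyl group on the pyrazoline core

A few compounds are considered here, and "the series" means these few. Any claim that something is new, unique, unknown or untested is made for them only; others in the source may bear on it.

Measured so far:
compound 1 `COc1cccc(C2CC(c3cc(OC)c(OC)c(OC)c3)=NN2C(C)=O)c1` — 44000 nM
compound 2 `COc1ccc(C2CC(c3cc(OC)c(OC)c(OC)c3)=NN2C(C)=O)cc1[N+](=O)[O-]` — 52000 nM
compound 3 `COc1ccc(C2CC(c3cc(OC)c(OC)c(OC)c3)=NN2)cc1O` — 500 nM

In a functional assay on L1210 cells (Mus musculus) for cytotoxicity, read by MTT assay, with a stated time of 72 h (a higher number here means a weaker inhibitor, a lower number a stronger inhibitor), compound 1 gives 44000 nM, the second highest of the three numbers. Compound 2 sits within the scatter of compound 1, so the two are read as equivalent. Compound 3 lies far below both, beyond the scatter, and is the one strong inhibitor of the set.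

Compound 4 `COc1ccccc1C1CC(c2cc(OC)c(OC)c(OC)c2)=NN1C(C)=O` is not yet measured. It differs from compound 1 in one place: 2-methoxyphenyl in place of 3-methoxyphenyl on a saturated ring carbon. The shared core and the acetyl group are unchanged; the two structures hold the same atoms joined differently.

Among the measured compounds shown here, no measured pair shows what this kind of shift does in this assay, so there is no step to lean on. The expected step from compound 1 to compound 4 is a 1.1-fold lower number from compound 1 to compound 4 (0.04 log units; within the scatter), that is, none beyond the scatter. Compound 4 is thus estimated at 40000 nM, with a range from 15000 nM to 110000 nM.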

Compound 4, half-maximal inhibitory concentration: 43000 nM
Estimate against measurement, compound 4: 1.1-fold (0.03 log units) below; the range from low to high includes it.
By their numbers in this assay, from the lowest: compound 3; then compounds 4, 1 and 2 (each within the scatter of the next).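

Among the compounds shown here, exchanging 3-methoxyphenyl for 2-methoxyphenyl on the saturated ring carbon gives a 1.0-fold lower number from compound 1 to compound 4 (0.01 log units; within the scatter) in this assay, and this is the first one-place step available. With the acetyl group and the shared core unchanged, this assay does not separate these two arrangements of the same atoms at this position. No available measurement offers an explanation for this result.

Going by these compounds, the shift is read only on the acetylated compounds, so it remains open whether 2-methoxyphenyl and 3-methoxyphenyl would also match without the acetyl group. On these data alone, compound 3 differs from each of the other compounds in more than one place, which leaves its low number unassigned to any single change, and the effect of an amine or a carboxylic acid on this phenyl ring also remains open.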